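A Methoxypyridine Ring in Place of a Fluorophenol

The source may report more compounds than this note shows. Statements on the series, on what has been measured and on what is new or still open speak of the compounds shown alone.

Going by the values given here, compound 1 `Oc1ccc(CN[C@@H]2CO[C@H](C(c3ccc(F)cc3)c3ccc(F)cc3)C[C@H]2O)cc1F` is one of two compounds measured in an assay on Cerebral cortex for inhibition of Norepinephrine transporter (Rattus norvegicus); on this read-out higher numbers stand for weaker inhibition and lower numbers for stronger inhibition. Compound 1 gives 7.37 nM, the lowest of the two numbers; the other, compound 2 `O[C@@H]1C[C@@H](C(c2ccccc2)c2ccccc2)OC[C@H]1NCc1ccc2occc2c1`, gives 33.6 nM, a gap beyond the usual scatter. Compound 3 `COc1ccc(CN[C@@H]2CO[C@H](C(c3ccc(F)cc3)c3ccc(F)cc3)C[C@H]2O)cn1` has not yet been measured. It differs from compound 1 in one place: 6-methoxypyridin-3-yl in place of 3-fluoro-4-hydroxyphenyl on a saturated chain carbon bound to an amine nitrogen. Among the compounds with values here, no step between measured compounds isolates this change, and compound 2 differs from compound 1 in more than one place, so its value can only be set beside that of compound 1 without explaining the gap. The author expects a modest weakening beyond the scatter, with the step from compound 1 to compound 3 in this assay estimated at a 2.7-fold higher number from compound 1 to compound 3 (0.43 log units; beyond the scatter). For compound 3 in this assay the author estimates 20 nM, within a range from 5 nM to 80 nM.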

Compound 3, inhibition constant: 28.4 nM
Compound 3: middle estimate off by 1.4-fold (0.15 log units), on the low side, within the range that was stated.
By their numbers in this assay, from the lowest: compound 1; then compounds 3 and 2 (each within the scatter of the next).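

Going by these compounds alone, on the saturated chain carbon bound to an amine nitrogen, 6-methoxypyridin-3-yl in place of 3-fluoro-4-hydroxyphenyl gives in this assay a 3.9-fold higher number from compound 1 to compound 3 (0.59 log units; beyond the scatter), the first step that isolates this position. The step is modest, so at this position a ring with a hetero atom and no hydrogen-bond donor keeps much of the inhibition, and a hydrogen-bond donor on this group is not essential for it. No measured property is available that bears on why the number rises.

The compounds shown leave open which part of the change carries the step, since the ring nitrogen, the methoxy group and the loss of fluorine and hydroxyl all come together. A 3-fluoro-4-methoxyphenyl group at the same place would separate the methoxy group from the ring nitrogen.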